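The compounds below may be only part of what the source reports. "The series", "measured", "known", "first", "only" and "open" are said of these compounds alone.

Measured so far:
Compound 1 `Cc1cc(N2CCNCC2)nc(SCc2nc3ccccc3[nH]2)n1`; in a functional assay on PC-3 cells (Homo sapiens) for cytotoxicity, read by MTT assay, with a stated time of 72 h (on this read-out lower numbers stand for stronger inhibition and higher numbers for weaker inhibition), compound 1 gives only the limit > 100000 nM.
Compound 2 `Cc1cc(NNC(N)=S)nc(SCc2nc3ccccc3[nH]2)n1`; in this assay compound 2 gives only the limit > 100000 nM.

Compound 1 thus stands at a limit rather than a number, and (the limit of > 100000 nM in this assay, at which 2 of the 2 values shown sit). Within the data shown here, the single measured step, a step that the two limits leave unreadable from compound 1 to compound 2, cannot be read in size. Compound 3 `Cc1cc(Nc2ccc(Cl)cc2)nc(SCc2nc3ccccc3[nH]2)n1` carries (4-chlorophenyl)amino in place of piperazin-1-yl on an aromatic carbon. Among the measured compounds shown here, no measured step bears on this change, and the two limits give no direction to expect beyond the scatter in this assay. Compound 3 is estimated at 60000 nM, range 10000 nM to 300000 nM. The step expected is an at least 1.6-fold lower number from compound 1 to compound 3 (0.22 log units; that floor lies within the scatter).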

Compound 3, half-maximal inhibitory concentration: 36000 nM
The estimate for compound 3 lay 1.7-fold (0.22 log units) above the measured number; measured number inside the range.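

Among these compounds, with (4-chlorophenyl)amino on this aromatic carbon of the shared core, this assay yields a number rather than a limit for the first time, and the change gives an at least 2.7-fold lower number from compound 1 to compound 3 (0.44 log units; beyond the scatter). The second comparison gives an at least 2.7-fold lower number from compound 2 to compound 3 (0.44 log units; beyond the scatter), so this position does respond to the group it carries, though both steps are floors and their full size stays unread. Compounds 1 and 2 remain limits, not numbers: the limit of > 100000 nM in this assay, at which 2 of the 3 values shown sit.

Going by these compounds, it remains open whether the chlorine or the aromatic ring accounts for the step. Plain phenylamino, 4-methoxyphenylamino and a benzylamine at this position would separate these.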